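The source may hold more compounds than are shown below. What is called first, only, known or untested is meant among the compounds shown, and "the series" means these compounds.

Compound 1 `CCCNC(=C\C(=O)/C=C/c1ccc(O)c(OC)c1)/C=C/c1ccc(O)c(OC)c1` and compound 2 `CCC(C)NC(=C\C(=O)/C=C/c1ccc(O)cc1)/C=C/c1ccc(O)cc1` share the same core and are tested in an ADME assay on Caco-2 cells (Homo sapiens) for inhibition, read by MTT assay, with a stated time of 72 h; a lower number here means a stronger inhibitor, a higher number a weaker inhibitor. In this assay compound 1 gives > 25000 nM, which is a limit of the assay and not a number. Compound 2 gives > 25000 nM in this assay, again a limit rather than a number. For the measured compounds named here, compound 1 thus stands only at a limit, as described by the limit of > 25000 nM in this assay, at which 2 of the 2 values shown sit, and no step between measured compounds is available. Compound 3 `COc1cc(/C=C/C(=O)/C=C(/C=C/c2ccc(O)c(OC)c2)NC2CCCCC2)ccc1O` differs from compound 1 in one place: cyclohexyl in place of propyl on an amine nitrogen The change reads propylamino to cyclohexylamino. Because of the limit of > 25000 nM in this assay, at which 2 of the 2 values shown sit, no step beyond the scatter is expected. The step that the limit leaves unreadable from compound 1 to compound 3 is expected to be small. Compound 3 is expected to give 30000 nM in this assay, with a range from 15000 nM to 80000 nM, and most likely only a limit would again be reported.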

Compound 3, half-maximal inhibitory concentration: > 25000 nM
Compound 3: a limit, no number; the forecaster's own chance of this, stated with the estimate: 85%; the middle value does not contradict the limit.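

Compound 3, like compound 1, gives only a limit in this assay and no number, so no step can be read for cyclohexyl in place of propyl on the amine nitrogen: the limit of > 25000 nM in this assay, at which 3 of the 3 values shown sit. The compounds shown leave open how strongly any of them inhibits and whether this change alters that inhibition at all.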